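Nitro in place of hydrogen on the core of compound 1

The source may hold more compounds than are shown below. What is called first, only, known or untested is meant among the compounds shown, and "the series" means these compounds.

Compound 1 `CC(C)(C)OC(=O)/C=C1/C(=O)Nc2ccccc21` is the parent of this small set. In a functional assay on MDA-MB-231 cells (Homo sapiens) for inhibition, read by CCK-8 assay, with a stated time of 72 h, tested at 20 uM (a higher number here means more inhibition of growth at the concentration tested, a lower number less inhibition of growth), compound 1 gives 87.6%, the highest of the three numbers recorded so far, though not separated from the other two beyond the scatter. Compound 2 `CN1C(=O)/C(=C/C(=O)OC(C)(C)C)c2ccccc21` carries a methyl in place of hydrogen on the amide-type nitrogen in the ring; in this assay compound 2 gives 86.6%, which amounts to a number 1 percentage points lower from compound 1 to compound 2 (within the scatter). Compound 3 `COc1ccc2c(c1)NC(=O)/C2=C/C(=O)OC(C)(C)C` carries a methoxy in place of hydrogen on an aromatic carbon; in this assay compound 3 gives 87.1%, which amounts to a number 0.5 percentage points lower from compound 1 to compound 3 (within the scatter).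

Compound 4 `CC(C)(C)OC(=O)/C=C1/C(=O)Nc2ccc([N+](=O)[O-])cc21` has not been measured. It differs from compound 1 by nitro in place of hydrogen on an aromatic carbon. Going by the values given here, of the measured steps, only the one from compound 1 to compound 3 concerns a substituent on an aromatic carbon of the core, and it stayed within the scatter; the step to compound 2 sits on the nitrogen and also stayed within the scatter. Nothing in the set shows a substituent moving the number beyond the scatter, so for compound 4 no step beyond the scatter is expected, estimated as a number 2.6 percentage points lower from compound 1 to compound 4 (within the scatter). Compound 4 is therefore expected to give about 85% in this assay, within a range of 70% to 93%.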

Compound 4, percent growth inhibition at one concentration: 86.9%
Estimate against measurement, compound 4: 1.9 percentage points below; measured number inside the range.
By their numbers in this assay, from the lowest: compounds 2, 4, 3 and 1 (each within the scatter of the next).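

In this assay, nitro in place of hydrogen on an aromatic carbon of the shared core gives a number 0.7 percentage points lower from compound 1 to compound 4 (within the scatter). This position, meta to a fused ring and para to a fused ring, therefore takes a group of 3 heavy atoms, with 2 hydrogen-bond acceptors and no hydrogen-bond donors, without the number leaving the scatter, and the methoxy of compound 3 is no longer the only aromatic-carbon substituent with a step inside the scatter. No available evidence bears on why the number holds with nitro at this position.

As far as these compounds go, whether an amine or a carboxylic acid on this same aromatic carbon would also stay within the scatter remains open, as does the outcome for a longer chain there. All four compounds were read at a single concentration, where their numbers lie close together, so the data leave open whether the nitro step would stay within the scatter in a full concentration series.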